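The compounds below may be only part of what the source reports. "The series", "measured", "known", "first", "only" and "open" are said of these compounds alone.

Compound 1 `O=C(NCc1ccc(S(=O)(=O)c2ccccc2)cc1)N1Cc2cccnc2C1`: > 2000 nM
Compound 2 `O=C(NCc1ccc(S(=O)(=O)c2cc(F)cc(F)c2)cc1)N1Cc2ccncc2C1`: 6.3 nM

Of the compounds shown here, two have been measured in a functional assay on A2780 cells (Homo sapiens) for cytotoxicity, read by sulforhodamine B assay, with a stated time of 72 h; a higher number here means a weaker inhibitor, a lower number a stronger inhibitor. For compound 1 the result is a limit of the assay and not a number, > 2000 nM. This is the limit of > 2000 nM in this assay, at which 1 of the 2 values shown sits, so compound 1 contributes no measured potency. Among the compounds with values here, compound 2 gives 6.3 nM in this assay, and it is the only number among the values shown. The other value, that of compound 1, is a limit of the assay. Compound 1 and compound 2 differ in more than one place, so nothing is said here about the size of the gap between them beyond what the two values show: one a number, the other a limit.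

Compound 3 `CC(=O)N1CCC(S(=O)(=O)c2ccc(CNC(=O)N3Cc4ccncc4C3)cc2)CC1` is not yet measured. It is made from compound 2 by a change on the sulfonyl sulfur: 1-acetylpiperidin-4-yl in place of 3,5-difluorophenyl on a sulfonyl sulfur. Within the data shown here, no measured pair here varies this position, so the expectation rests on the structural change alone, and an aromatic ring of carbon giving way to a six-membered non-aromatic ring with one hetero atom is a considerable change. Compound 3 is expected to sit weaker than compound 2 in this assay, with the step from compound 2 to compound 3 estimated at a 16-fold higher number from compound 2 to compound 3 (1.20 log units; beyond the scatter), beyond the usual scatter. The estimate for compound 3 in this assay is 100 nM, with a range from 15 nM to 1000 nM.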

Compound 3, half-maximal inhibitory concentration: 110 nM
Beside the measured number, compound 3's estimate is 1.1-fold (0.04 log units) below it; low and high end bracket the measured number.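

In this assay, within the data shown here, the group on the sulfonyl sulfur varies in a single place for the first time, and 1-acetylpiperidin-4-yl in place of 3,5-difluorophenyl gives a 17-fold higher number from compound 2 to compound 3 (1.24 log units; beyond the scatter), so this position answers clearly to this change. An aromatic ring of carbon is nevertheless not needed on the sulfur for a measured value, since compound 3, with a six-membered non-aromatic ring carrying 1 hetero atom there, gives 110 nM and not a limit of the assay. Nothing in the data shown explains the size of this step.

The step replaces the aromatic ring, brings in the ring nitrogen and adds the acetyl group all at once, so the compounds shown do not divide it among these parts. Going by these compounds, it remains open how the shared core would respond to a piperidin-4-yl without the acetyl group, to a cyclohexyl ring or to an unsubstituted phenyl ring on the sulfonyl sulfur, and each of these would separate one part of the change from the others.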